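Adding an Isobutyl Group to a Phenyl Ring

A few compounds are considered here, and "the series" means these few. Any claim that something is new, unique, unknown or untested is made for them only; others in the source may bear on it.

Three measured compounds share one core and were tested in an assay on Prostate gland (Oryctolagus cuniculus) for inhibition of Adrenergic receptor alpha-1 (Homo sapiens); on this read-out higher numbers stand for weaker binding and lower numbers for tighter binding. Compound 1, `COc1ccccc1N1CCN(CCCOc2ccc(C(=O)Nc3ccccc3OCCCC(=O)O)cc2)CC1`, gives 100 nM in this assay. Compound 2, `COc1ccccc1N1CCN(CCCCCCOc2ccc(C(=O)Nc3ccccc3OCCCC(=O)O)cc2)CC1`, gives 100 nM in this assay. Compound 3, `COc1ccccc1N1CCN(CCC(Oc2ccc(NC(=O)c3ccccc3OCCCC(=O)O)cc2)c2ccccc2)CC1`, gives 79.4 nM in this assay, which is the lowest of the three numbers, yet the gap to compound 1 and the gap to compound 2 both lie within the scatter of repeated measurements, so the three compounds cannot be told apart on these numbers.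

Compound 4, `COc1ccccc1N1CCN(CCC(Oc2ccc(NC(=O)c3ccccc3OCCCC(=O)O)cc2)c2ccc(CC(C)C)cc2)CC1`, has not yet been measured. It differs from compound 3 by isobutyl in place of hydrogen on an aromatic carbon. Going by the values given here, no pair of the measured compounds shows a step of this kind, so there is no measured step on which to rest a forecast. The expectation rests on the structural change alone. A step that is small, at most a little beyond the scatter and toward a lower number, is expected from compound 3 to compound 4, namely a 1.3-fold lower number from compound 3 to compound 4 (0.10 log units; within the scatter). For compound 4 in this assay the estimate is 63 nM, with a range expected from 20 nM to 200 nM.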

Compound 4, dissociation constant: 6310 nM
Estimate against measurement, compound 4: 100-fold (2.00 log units) below; the measured number lies above the stated range.
By their numbers in this assay, from the lowest: compounds 3, 1 and 2 (each within the scatter of the next); then compound 4.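

In this assay, going by these compounds alone, isobutyl in place of hydrogen on an aromatic carbon, para to a large group, brings a 79-fold higher number from compound 3 to compound 4 (1.90 log units; beyond the scatter), a large move toward weaker binding that the earlier compounds, with no step of this kind among them, gave no means of foreseeing. Within the data shown here, the single step shows that this position on the phenyl ring does not accept every addition freely, since four carbons entering at this one place are enough to carry the number far beyond the scatter. Nothing available explains why the number moves this far, and the result is recorded here as an observation only.

The compounds shown leave open whether this step belongs to isobutyl in particular or would also appear with a smaller group at the same carbon, such as methyl, a fluorine atom or a methoxy group. They also leave open whether a polar group such as an amine or a hydroxyl at this place would behave in the same way, and whether isobutyl on another carbon of this ring would bring a step of similar size.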